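Replacing Fluorine with a Carboxyethyl Amide on the Shared Core

This account rests on a few compounds, and the source may have more. Where it says the series, first, only, none or still open, it means among the compounds named here.

Compound 1 `Fc1ccc(-c2nc3cc(C(F)(F)F)ccc3[nH]2)cc1`, compound 2 `CC(=O)Nc1ccc(-c2nc3ccccc3[nH]2)cc1` and compound 3 `O=C(CN1CCCCC1)Nc1ccc(-c2nc3ccccc3[nH]2)cc1` share one core and differ in a single substituent. In an ADME assay on BHK cells (Mesocricetus auratus) for cytotoxicity, read by MTT assay, with a stated time of 96 h (a lower number here means that less compound is tolerated, a higher number that more compound is tolerated), compound 1 gives 25000 nM, and compound 3 gives 31000 nM, a gap within the usual scatter. For compound 2 the assay reports only a limit, > 100000 nM. The step of an at least 3.2-fold lower number from compound 2 to compound 3 (0.50 log units; beyond the scatter) shows that adding piperidin-1-yl to the chain carbon made less compound tolerated. Compound 4 `O=C(O)CCC(=O)Nc1ccc(-c2nc3cc(C(F)(F)F)ccc3[nH]2)cc1` is not yet measured; it differs from compound 1 by ((2-carboxyethyl)carbonyl)amino in place of fluoro on an aromatic carbon. Going by the values given here, no measured step swaps fluoro for such an amide directly, yet compound 2 at its limit of > 100000 nM in this assay, at which 1 of the 3 values shown sits, shows an amide-bearing analogue being well tolerated. A modest rise is expected, a 2.0-fold higher number from compound 1 to compound 4 (0.30 log units; within the scatter). Compound 4 is therefore estimated at 50000 nM, within a range from 15000 nM to 150000 nM.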

Compound 4, half-maximal cytotoxic concentration: > 100000 nM
Compound 4 was reported as a limit; the forecaster's own chance of this, stated with the estimate: 30%; at least 2.0-fold (0.30 log units) between middle value and limit.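

In this assay, the swap of fluoro for ((2-carboxyethyl)carbonyl)amino gives an at least 4.0-fold higher number from compound 1 to compound 4 (0.60 log units; beyond the scatter), so a change at this aromatic carbon alone moves the result past the usual scatter, towards more compound being tolerated. The result for compound 4 is a limit, not an exact number. Compound 4 now sits at the same limit as another compound: the limit of > 100000 nM in this assay, at which 2 of the 4 values shown sit.

On these data alone, whether the whole chain or only its amide part matters remains open. It is also unknown how a plain amine, a longer chain or an ester in place of the carboxylic acid would behave at this position.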